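Methoxy versus bromo on the indole of compound 1

The compounds below may be only part of what the source reports. "The series", "measured", "known", "first", "only" and "open" are said of these compounds alone.

Working notes on a small set of benzimidazole-bearing indoles. The reference point is compound 1 `COc1ccc2c(c1)c(-c1nc3ccccc3n1C(=O)c1ccccc1)cn2C`, which in a functional assay on HepG2 cells (Homo sapiens) for inhibition, read by MTT assay, with a stated time of 24 h (on this read-out lower numbers stand for stronger inhibition of growth and higher numbers for weaker inhibition of growth), gives 37900 nM. Compound 2 `COc1cccc(C(=O)n2c(-c3cn(C)c4ccc(OC)cc34)nc3ccccc32)c1` differs from it by hydrogen in place of methoxy on an aromatic carbon and gives 11700 nM, the step being a 3.2-fold lower number from compound 1 to compound 2 (0.51 log units; beyond the scatter). Compound 3 `COc1ccc2c(c1)c(-c1nc3ccccc3n1C(=O)c1cccc(Br)c1)cn2C` gives 51300 nM; against compound 1 the step is a 1.4-fold higher number from compound 1 to compound 3 (0.13 log units; within the scatter), and against compound 2 it is a 4.4-fold higher number from compound 2 to compound 3 (0.64 log units; beyond the scatter), which marks the change (bromo in place of methoxy on an aromatic carbon).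

The unmeasured compound 4 `Cn1cc(-c2nc3ccccc3n2C(=O)c2ccccc2)c2cc(Br)ccc21` carries the same kind of change as compound 2 to compound 3, but at a different place: bromo in place of methoxy on an aromatic carbon. Around that place the ring is part of a fused or bridged system of two rings, meta to a fused ring and para to a fused ring, whereas in compound 3 the substituent sits meta to a large group on a single ring.

The change occurs twice in all among these compounds. The measured instance gave a 4.4-fold higher number from compound 2 to compound 3 (0.64 log units; beyond the scatter). For compound 4 a step of roughly a 1.6-fold higher number from compound 1 to compound 4 (0.20 log units; within the scatter) is expected, resting on that single measured step from compound 2 to compound 3 and tempered by the different surroundings. The estimate for compound 4 in this assay is 60000 nM, within 22000 nM to 160000 nM.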

Compound 4, concentration for 50% growth inhibition: 48100 nM
Compound 4: middle estimate off by 1.2-fold (0.10 log units), on the high side; measured number inside the range.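

In this assay, bromo in place of methoxy on an aromatic carbon of the fused system gives a 1.3-fold higher number from compound 1 to compound 4 (0.10 log units; within the scatter), so at this place the change leaves the number within the scatter. The change therefore does not carry over at one size from one core to the other: the same change on two cores in this assay, a 4.4-fold higher number (0.64 log units; beyond the scatter) from compound 2 to compound 3 and a 1.3-fold higher number (0.10 log units; within the scatter) from compound 1 to compound 4, 3.5-fold (0.54 log units) apart, beyond the scatter of two such steps. The two instances differ in place as well as in core, and with a single step for each, the compounds show neither what produces the gap nor what size to expect on a further core.

Open, on these data alone, is whether the small step at this place holds for other groups, such as an amine or a carboxylic acid in place of methoxy on the same aromatic carbon. Also open, as far as these compounds go, is whether bromo in place of methoxy at both places on one core would give steps of the same size as those seen here, which would separate the effect of place from that of core.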